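The compounds below may be only part of what the source reports. "The series", "measured", "known", "first", "only" and "open" are said of these compounds alone.

Working notes on the series, read in a functional assay on U-87MG ATCC cells for antiproliferative activity against U-87 MG (Homo sapiens), read by MTT assay, with a stated time of 72 h; on this read-out higher numbers stand for weaker inhibition and lower numbers for stronger inhibition. Compound 1 `O=C(Nc1ccc(Oc2ccnc3[nH]ccc23)cc1)c1cc2cccnc2n(-c2ccccc2)c1=O` gives 1580 nM in this assay. Compound 2 `O=C(Nc1ccc(Oc2ccnc3[nH]ccc23)c(F)c1)c1cc2cccnc2n(-c2ccccc2)c1=O` carries the change fluoro in place of hydrogen on an aromatic carbon and gives 1260 nM in this assay; the step is a 1.3-fold lower number from compound 1 to compound 2 (0.10 log units; within the scatter). Compound 3 `Cn1ccc2c(Oc3ccc(NC(=O)c4cc5cccnc5n(-c5ccccc5)c4=O)cc3F)ccnc21` gives 3590 nM in this assay; the step is a 2.8-fold higher number from compound 2 to compound 3 (0.45 log units; beyond the scatter). The difference between the cores of compound 1 and compound 3 is not broken down here. Compound 4 `Cn1ccc2c(Oc3ccc(NC(=O)c4cc5cccnc5n(-c5ccc(F)cc5)c4=O)cc3F)ccnc21` is not yet measured; it differs from compound 3 by fluoro in place of hydrogen on an aromatic carbon. This is the same kind of change as from compound 1 to compound 2, not the same: there the place was ortho to a large group and meta to a large group, here it is para to a large group. Resting on the step of a 1.3-fold lower number from compound 1 to compound 2 (0.10 log units; within the scatter), a small step is expected, a 1.2-fold lower number from compound 3 to compound 4 (0.08 log units; within the scatter). Compound 4 is estimated at 3000 nM, with a range from 1400 nM to 6500 nM.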

Compound 4, half-maximal inhibitory concentration: 1320 nM
Compound 4: the middle estimate sits 2.3-fold (0.36 log units) above what was measured; measured number outside the range, below it.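

In this assay, the change from phenyl to 4-fluorophenyl gives a 2.7-fold lower number from compound 3 to compound 4 (0.43 log units; beyond the scatter). Set beside the earlier fluoro step, the two results cannot be told apart, so nothing here argues against the change carrying from one core to the other: the same change on two cores in this assay, a 1.3-fold lower number (0.10 log units; within the scatter) from compound 1 to compound 2 and a 2.7-fold lower number (0.43 log units; beyond the scatter) from compound 3 to compound 4, 2.2-fold (0.34 log units) apart, within the scatter of two such steps This does not establish a fixed size for the step, since each core supplies a single pair and the fluoro stands at a different place in each pair, leaving the effects of core and place unseparated.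

On these data alone, it remains open whether 4-fluorophenyl gives a similar step on the core of compound 1. As far as these compounds go, it also remains open how chloro, methoxy or an amine at the same place would read.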